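The source may report more compounds than this note shows. Statements on the series, on what has been measured and on what is new or still open speak of the compounds shown alone.

Measured so far:
compound 1 `COc1ccc(C(=O)/C=C/c2ccc(F)cc2)c2c1C=CC(C)(C)O2`: > 10000 nM
compound 2 `CCOc1cc(/C=C/C(=O)c2ccc(OC)c3c2OC(C)(C)C=C3)ccc1O`: > 10000 nM

Of the compounds shown here, two sharing one core have been tested in a functional assay on SW-620 cells (Homo sapiens) for antiproliferative activity, read by MTT assay, with a stated time of 24 h; on this read-out lower numbers stand for stronger inhibition and higher numbers for weaker inhibition. For compound 1 the result is a limit of the assay, > 10000 nM. For compound 2 the result is likewise a limit, > 10000 nM. Neither value is a number; both sit at the limit of > 10000 nM in this assay, at which 2 of the 2 values shown sit, so no order between them can be told, and compound 2 stands at the limit like every other value shown.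

Compound 3 `COc1ccc(C(=O)/C=C/c2ccc(O)c(Br)c2)c2c1C=CC(C)(C)O2` has not yet been measured. It differs from compound 2 in one place: bromo in place of ethoxy on an aromatic carbon. Within the data shown here, no step between measured compounds exists to guide an expectation, and the two results available give no ranking. On that basis no step beyond the usual scatter is expected in this assay, and compound 3 is expected to stay at or near the limit. The estimate for compound 3 is 15000 nM, between 3000 nM and 60000 nM. The implied step is expected to be a step that the limit leaves unreadable from compound 2 to compound 3.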

Compound 3, half-maximal inhibitory concentration: > 10000 nM
Compound 3 ended at the assay's limit; the forecaster's own chance of this, stated with the estimate: 70%; the middle value does not contradict the limit.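

In this assay, among these compounds, compound 1, compound 2 and compound 3 each give a limit of the assay rather than a number, so no step among them can be read: the limit of > 10000 nM in this assay, at which 3 of the 3 values shown sit. The compounds shown leave open how strongly any of the three acts on these cells, and whether the groups that differ among them matter at all.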